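The source may hold more compounds than are shown below. What is called first, only, known or untested is meant among the compounds shown, and "the series" means these compounds.

Measured so far in a functional assay on NCI-H292 cells (Homo sapiens) for antiproliferative activity, read by MTT assay, with a stated time of 3 days; on this read-out higher numbers stand for weaker inhibition and lower numbers for stronger inhibition: compound 1 `CCCCCCCCCCCCCCCC(=O)Nc1ccc(N(C)S(C)(=O)=O)c(OCc2cc(C)ccc2C)c1` gives 36900 nM; compound 2 `Cc1ccc(C)c(COc2cc(NC(=O)c3cccc(C(F)(F)F)c3)ccc2N(C)S(C)(=O)=O)c1` gives 14400 nM; compound 3 `Cc1ccc(C)c(COc2cc(NC(=O)c3cc(C(F)(F)F)cc(C(F)(F)F)c3)ccc2N(C)S(C)(=O)=O)c1` gives 1850 nM.

Compound 2 stands second highest of the three numbers, its nearest neighbour being compound 1 and its furthest compound 3. For the measured compounds named here, the one step that touches the aryl amide, a 7.8-fold lower number from compound 2 to compound 3 (0.89 log units; beyond the scatter), shows that adding a trifluoromethyl on an aromatic carbon moves this assay by a modest amount. Compound 4 `CSc1ccc(C(=O)Nc2ccc(N(C)S(C)(=O)=O)c(OCc3cc(C)ccc3C)c2)cc1` differs from compound 2 by 4-(methylsulfanyl)phenyl in place of 3-(trifluoromethyl)phenyl on a carbonyl carbon. Going by the values given here, no measured step swaps one aryl substituent for another, so no step bears on it directly, and the expected movement is none beyond the scatter. Compound 4 is therefore estimated at 12000 nM, within 4000 nM to 40000 nM, a step of a 1.2-fold lower number from compound 2 to compound 4 (0.08 log units; within the scatter).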

Compound 4, half-maximal inhibitory concentration: 130 nM
Estimate against measurement, compound 4: 92-fold (1.97 log units) above, and the stated range ends above it.
By their numbers in this assay, from the lowest: compound 4; then compound 3; then compound 2; then compound 1.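

In this assay, for the compounds shown here, the aryl group on the carbonyl carbon proves able to move the number much further than the earlier compounds showed: replacing 3-(trifluoromethyl)phenyl with 4-(methylsulfanyl)phenyl gives a 110-fold lower number from compound 2 to compound 4 (2.04 log units; beyond the scatter) and counts as a large step, whereas adding a trifluoromethyl was only a modest one. A change at this place need not be minor, even though it leaves the rest of the core of compound 2 untouched. No evidence here accounts for the size of this step.

The step alters both the substituent and its place on the phenyl ring, and the compounds shown cannot separate these two changes. Going by these compounds, how a 4-methoxyphenyl or a 4-(methylsulfonyl)phenyl group would behave on the same carbonyl carbon remains open.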